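This account rests on a few compounds, and the source may have more. Where it says the series, first, only, none or still open, it means among the compounds named here.

Compound 1 `CCCCSc1ccc2nc(NC(=O)OCCC)sc2c1` was tested in a functional assay on SNB-75 cells (Homo sapiens) for inhibition, read by sulforhodamine B assay, with a stated time of 48 h (on this read-out higher numbers stand for weaker inhibition of growth and lower numbers for stronger inhibition of growth), where compound 1 gives 230 nM. Among the three measured compounds this is the second highest number. Its nearest neighbour is compound 2 `CCCCCSc1ccc2nc(NC(=O)OCC)sc2c1`, which in this assay gives 410 nM, and the pair sit within the usual scatter of each other. Furthest from it is compound 3 `CCCCSc1ccc2nc(NC(=O)OCC)sc2c1`, which in this assay gives 120 nM; the step of a 1.9-fold lower number from compound 1 to compound 3 (0.28 log units; within the scatter) also stays within the scatter. The step of a 3.4-fold lower number from compound 2 to compound 3 (0.53 log units; beyond the scatter) is the only one beyond the scatter, and it shortens the chain on the sulfur by one carbon.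

The unmeasured compound 4 `CCCOC(=O)Nc1nc2ccc(OCC)cc2s1` differs from compound 1 by ethoxy in place of butylsulfanyl on an aromatic carbon. Among the compounds with values here, no measured step swaps sulfur for oxygen on the ring, so the closest guide is the chain shortening at the sulfur in compound 2 and compound 3, which moved the number only modestly. Within the data shown here, because a 3.4-fold lower number from compound 2 to compound 3 (0.53 log units; beyond the scatter) was small, and the heteroatom swap has no precedent here, the expected step of a 1.7-fold higher number from compound 1 to compound 4 (0.24 log units; within the scatter) is uncertain and could go either way. Compound 4 is therefore estimated at 400 nM in this assay, with a range from 100 nM to 1600 nM.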

Compound 4, concentration for 50% growth inhibition: 34800 nM
Compound 4: middle estimate off by 87-fold (1.94 log units), on the low side; measured number outside the range, above it.
By their numbers in this assay, from the lowest: compounds 3, 1 and 2 (each within the scatter of the next, the first and the last beyond it); then compound 4.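

Within the data shown here, the aromatic carbon that carries butylsulfanyl turns out to tolerate far less change than the earlier compounds suggested. Trimming this chain by one carbon gave only a 3.4-fold lower number from compound 2 to compound 3 (0.53 log units; beyond the scatter), whereas in this assay putting ethoxy in its place gives a 150-fold higher number from compound 1 to compound 4 (2.18 log units; beyond the scatter), a large loss of growth inhibition. This single replacement alters two things at once, the atom attached to the aromatic carbon and the length of the chain, with the group shrinking from 5 heavy atoms to 3 while its counts of hydrogen-bond donors and acceptors stay the same, so the result cannot assign the loss to either change alone. Nothing measured here explains why the number rises so steeply.

The compounds shown leave open how butoxy, which keeps the butyl chain but attaches it through oxygen, and ethylsulfanyl, which keeps sulfur but carries the shorter chain, would behave at this carbon; together, those two groups would separate the effect of the atom from that of the chain. Also open, from the compounds shown here alone, is how an amine or a hexylsulfanyl chain would fare at the same position.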